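Changing the Branched Alkyl Group: Compound 2 to Compound 3

The source may report more compounds than this note shows. Statements on the series, on what has been measured and on what is new or still open speak of the compounds shown alone.

Measured compounds:
compound 1, `N#CN/C(=N\c1ccccc1)Nc1cccnc1`, 5 mg/kg
compound 2, `CCC(CC)/N=C(\NC#N)Nc1ccncc1`, 2.5 mg/kg

Both compounds were tested in a functional assay on the whole organism (blood, strain Wistar-Okamoto) with Rattus norvegicus as the target, with a stated time of 5 days; on this read-out higher numbers stand for an effect only at larger amounts of compound and lower numbers for an effect already at smaller amounts. In this assay compound 2 gives 2.5 mg/kg, and compound 1 gives 5 mg/kg. Compound 2 thus holds the lower of the two numbers shown, but its gap to compound 1 lies within the usual scatter, so the two compounds cannot be told apart on these data, and no step between them is known.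

The next compound to be measured is compound 3, `CCC(C)C(C)/N=C(\NC#N)Nc1ccncc1`. It differs from compound 2 in a single place: 1,2-dimethylbutyl in place of pentan-3-yl on a double-bonded nitrogen. The group that leaves and the group that enters both carry no ring, no hydrogen-bond donor and no hydrogen-bond acceptor, and differ by one carbon in their count.

Among the measured compounds shown here, with only two measured compounds, and no step between them beyond the scatter, there is nothing in these data that points to a change in one direction. The step from compound 2 to compound 3 is therefore expected to be no change at the digits printed from compound 2 to compound 3 (within the scatter), that is, none beyond the scatter. For compound 3 the expected value in this assay is 2.5 mg/kg, with a likely range from 1.2 mg/kg to 6 mg/kg.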

Compound 3, minimum effective dose: 8 mg/kg
Compound 3: middle estimate off by 3.2-fold (0.51 log units), on the low side; measured number outside the range, above it.
By their numbers in this assay, from the lowest: compounds 2, 1 and 3 (each within the scatter of the next, the first and the last beyond it).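

In this assay, among the compounds shown here, the position on the double-bonded nitrogen turns out to be sensitive to the alkyl group it carries: 1,2-dimethylbutyl in place of pentan-3-yl gives the first step in this small set that lies beyond the usual scatter (a 3.2-fold higher number from compound 2 to compound 3 (0.51 log units; beyond the scatter)). The step is modest, but it runs towards a larger amount of compound being needed for an effect, and it comes from a swap between two open chains, neither of which carries a ring, a hydrogen-bond donor or a hydrogen-bond acceptor. Nothing measured here explains why the number rises.

This single step cannot separate the larger carbon count of the new group from the different shape of its branching, since both change together between compound 2 and compound 3. From the compounds shown here alone, how the number would respond to a smaller isopropyl group, an unbranched hexyl chain, a cyclohexyl ring or a chain ending in an amine at this same place remains open.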